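Smaller acyl group on the piperidine nitrogen of compound 1

The source may report more compounds than this note shows. Statements on the series, on what has been measured and on what is new or still open speak of the compounds shown alone.

Compound 1 `Cn1cncc1CN1CC(N(CC2CCN(C(=O)c3ccc(Cl)cc3)CC2)S(=O)(=O)c2ccccn2)Cc2cc(C#N)ccc21` is one of three close analogues whose permeability has been measured in an ADME assay on Caco-2 cells (Homo sapiens) for permeability, in the apical to basolateral direction; on this read-out lower numbers stand for lower permeability and higher numbers for higher permeability. In this assay compound 1 gives 0.5 10^-6 cm/s, the second highest of the three numbers; compound 3 `Cn1cncc1CN1CC(N(CC2CCN(C(=O)NC(C)(C)C)CC2)S(=O)(=O)c2ccccn2)Cc2cc(C#N)ccc21` gives 0.6 10^-6 cm/s, and compound 2 `Cn1cncc1CN1CC(N(CC2CCN(S(C)(=O)=O)CC2)S(=O)(=O)c2ccccn2)Cc2cc(C#N)ccc21` gives 0.1 10^-6 cm/s. Between these, a 1.2-fold higher number from compound 1 to compound 3 (0.08 log units; within the scatter), whereas a 5.0-fold lower number from compound 1 to compound 2 (0.70 log units; beyond the scatter) and a 6.0-fold higher number from compound 2 to compound 3 (0.78 log units; beyond the scatter).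

Compound 4 `C=C(C)C(=O)N1CCC(CN(C2Cc3cc(C#N)ccc3N(Cc3cncn3C)C2)S(=O)(=O)c2ccccn2)CC1` differs from compound 1 at the same carbonyl carbon: 1-methylethenyl in place of 4-chlorophenyl on a carbonyl carbon. Of the measured steps, the one that bears most directly on this change is the exchange at the carbonyl carbon, where a 1.2-fold higher number from compound 1 to compound 3 (0.08 log units; within the scatter); the larger drop seen when the whole (4-chlorophenyl)carbonyl is exchanged, a 5.0-fold lower number from compound 1 to compound 2 (0.70 log units; beyond the scatter), involves a different group on the ring nitrogen and so is a weaker guide. With the carbonyl retained and only its substituent changed, the expectation is therefore a change in this assay that stays within or close to the scatter, leaning slightly downward.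

On that basis compound 4 is expected to show 0.4 10^-6 cm/s in this assay, within a range of 0.15 10^-6 cm/s to 1 10^-6 cm/s. This estimate corresponds to an expected step of a 1.3-fold lower number from compound 1 to compound 4 (0.10 log units; within the scatter).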

Compound 4, apparent permeability: 0.5 10^-6 cm/s
Compound 4: the middle estimate sits 1.3-fold (0.10 log units) below what was measured, and the stated range covers the measured number.
By their numbers in this assay, from the lowest: compound 2; then compounds 1, 4 and 3 (each within the scatter of the next).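

In this assay, 1-methylethenyl in place of 4-chlorophenyl on a carbonyl carbon, a group without a ring and with fewer heavy atoms, gives no change at the digits printed from compound 1 to compound 4 (within the scatter) and 1-methylethenyl in place of (tert-butyl)amino on that carbon gives a 1.2-fold lower number from compound 3 to compound 4 (0.08 log units; within the scatter) so the three substituents tried on this carbonyl carbon now all lie within the scatter of one another. Set against methylsulfonyl on the amine nitrogen in a ring, (1-methylethenyl)carbonyl gives a 5.0-fold higher number from compound 2 to compound 4 (0.70 log units; beyond the scatter) so all three compounds with a carbonyl on that nitrogen stand apart from compound 2, the one compound without it. No available evidence accounts for this result.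

As far as these compounds go, it remains open whether the flat reading would hold for a substituent on the carbonyl carbon that carries an amine or a carboxylic acid, or for a longer chain there. From the compounds shown here alone, it is also open whether another group without a carbonyl on that nitrogen, such as a plain methyl, would read like compound 2, so the low number of compound 2 cannot yet be tied to the absence of the carbonyl rather than to methylsulfonyl itself.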